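Fluorine position on the aryl cyclopropane of the series

This account rests on a few compounds, and the source may have more. Where it says the series, first, only, none or still open, it means among the compounds named here.

Measured in a functional assay for agonist activity at G protein-coupled receptor 88 (Homo sapiens), read by HTRF and cAMP accumulation; a higher number here means that more compound is needed for the effect, a lower number that less compound is needed:
compound 1 `CC[C@H](C)[C@H](N)CN(C(=O)[C@@H]1C[C@H]1c1cccc(Cl)c1)c1ccc(-c2ccccc2)cc1` gives 2200 nM
compound 2 `CC[C@H](C)[C@H](N)CN(C(=O)[C@@H]1C[C@H]1c1cccc(OC)c1)c1ccc(-c2ccccc2)cc1` gives 3000 nM
compound 3 `CC[C@H](C)[C@H](N)CN(C(=O)[C@@H]1C[C@H]1c1cccc(F)c1)c1ccc(-c2ccccc2)cc1` gives 560 nM

Compound 3 stands lowest of the three numbers in this assay. The steps to it are a 3.9-fold lower number from compound 1 to compound 3 (0.59 log units; beyond the scatter) and a 5.4-fold lower number from compound 2 to compound 3 (0.73 log units; beyond the scatter), both beyond the scatter, while the step of a 1.4-fold higher number from compound 1 to compound 2 (0.13 log units; within the scatter) is within it. So among the three groups tried on that aromatic ring, fluoro gives the lowest number by a clear but modest margin; there are too few compounds to call this a pattern beyond the three.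

Compound 4 `CC[C@H](C)[C@H](N)CN(C(=O)[C@@H]1C[C@H]1c1ccccc1F)c1ccc(-c2ccccc2)cc1` keeps the fluoro but changes where it sits: 2-fluorophenyl in place of 3-fluorophenyl on a saturated ring carbon. Among the measured compounds shown here, none of the measured steps moves a group around the ring; each swaps one group for another at a single position. They therefore bear on the new step only indirectly, showing that changes on this ring have so far shifted the number by modest amounts, not by large ones. For the measured compounds named here, with no direct precedent, the expectation for compound 4 in this assay is a number somewhat above that of compound 3 and a broad range: compound 4 is estimated at 1100 nM, between 350 nM and 3500 nM. The expected step is a 2.0-fold higher number from compound 3 to compound 4 (0.29 log units; within the scatter).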

Compound 4, half-maximal effective concentration: 650 nM
Compound 4: the middle estimate sits 1.7-fold (0.23 log units) above what was measured; the range from low to high includes it.
By their numbers in this assay, from the lowest: compounds 3 and 4 (each within the scatter of the next); then compounds 1 and 2 (each within the scatter of the next).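

In this assay, among the compounds shown here, moving the fluoro gives a 1.2-fold higher number from compound 3 to compound 4 (0.06 log units; within the scatter), so 3-fluorophenyl and 2-fluorophenyl cannot be told apart on this saturated ring carbon, and the earlier compounds, which only exchanged one group for another, could not show this. Compound 4 also stands clear of the other two groups, with a 4.6-fold lower number from compound 2 to compound 4 (0.66 log units; beyond the scatter) and a 3.4-fold lower number from compound 1 to compound 4 (0.53 log units; beyond the scatter), so the lower numbers now go with fluoro at two placements on the ring rather than with a single compound, although these two steps change both the group and its placement. Nothing measured in the material at hand accounts for how little the placement matters in this pair of compounds.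

On these data alone, whether chloro or methoxy would behave like fluoro under the same move stays open, so the link between fluoro and the lower numbers rests on compound 3 and compound 4 alone. Also open, as far as these compounds go, is how this aryl ring responds to groups of other kinds, such as a nitrile, a trifluoromethyl or an amine, or to a second fluorine as in a difluorophenyl.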